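From hydroxy to dimethylamino on a shared core

The source may hold more compounds than are shown below. What is called first, only, known or untested is meant among the compounds shown, and "the series" means these compounds.

Measured in a functional assay on A549 cells (Homo sapiens) for inhibition, read by sulforhodamine B assay; a lower number here means a stronger inhibitor of growth, a higher number a weaker inhibitor of growth:
Compound 1 `Fc1ccc(-c2ccc(-c3ccc(-c4nc5ccccc5[nH]4)cc3)cc2)cc1`: 33200 nM
Compound 2 `FC(F)(F)Oc1ccc(-c2ccc(-c3ccc(-c4nc5ccccc5[nH]4)cc3)cc2)cc1`: 38000 nM
Compound 3 `Oc1ccc(-c2ccc(-c3ccc(-c4nc5ccccc5[nH]4)cc3)cc2)cc1`: 33100 nM

Compound 3, at 33100 nM, lies within the scatter of the other two measured compounds. Compound 4 `CN(C)c1ccc(-c2ccc(-c3ccc(-c4nc5ccccc5[nH]4)cc3)cc2)cc1` carries dimethylamino in place of hydroxy on an aromatic carbon, para to a large group: dimethylamino in place of hydroxy on an aromatic carbon. Three measured steps at this position bear on the change: a 1.1-fold higher number from compound 1 to compound 2 (0.06 log units; within the scatter), a 1.0-fold lower number from compound 1 to compound 3 (0.00 log units; within the scatter) and a 1.1-fold lower number from compound 2 to compound 3 (0.06 log units; within the scatter). Among the measured compounds shown here, all three stay within the scatter, although no measured compound carries dimethylamino. No step beyond the scatter is therefore expected in this assay. The expected step is a 1.0-fold lower number from compound 3 to compound 4 (0.01 log units; within the scatter). Compound 4 is estimated at 32000 nM, with an expected range of 14000 nM to 60000 nM.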

Compound 4, concentration for 50% growth inhibition: 30100 nM
The estimate for compound 4 lay 1.1-fold (0.03 log units) above the measured number; low and high end bracket the measured number.
By their numbers in this assay, from the lowest: compounds 4, 3, 1 and 2 (each within the scatter of the next).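

In this assay, dimethylamino in place of hydroxy gives a 1.1-fold lower number from compound 3 to compound 4 (0.04 log units; within the scatter), and the steps from the other two groups, a 1.3-fold lower number from compound 2 to compound 4 (0.10 log units; within the scatter) and a 1.1-fold lower number from compound 1 to compound 4 (0.04 log units; within the scatter), also stay within the scatter. An amine on this aromatic carbon therefore joins fluoro, trifluoromethoxy and hydroxy in a single band of numbers, and losing the hydroxy hydrogen-bond donor moves nothing beyond the scatter. Nothing at hand accounts for this.

From the compounds shown here alone, it remains open whether a carboxylic acid or a longer chain ending in an amine at this position would leave that band.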